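A few compounds are considered here, and "the series" means these few. Any claim that something is new, unique, unknown or untested is made for them only; others in the source may bear on it.

Of the compounds shown here, three built on one shared core have been tested in a functional assay on MCF7 cells (Homo sapiens) for antiproliferative activity, read by sulforhodamine B assay, with a stated time of 48 h; on this read-out lower numbers stand for stronger inhibition and higher numbers for weaker inhibition. Compound 1 `CCCCCc1ccc(NS(=O)(=O)c2ccc(N3CCNC3=O)cc2)cc1` carries a pentyl chain, and in this assay compound 1 gives > 1000 nM, a limit of the assay rather than a number. Compound 2 `O=C1NCCN1c1ccc(S(=O)(=O)Nc2ccc(C3CCCCC3)cc2)cc1` carries a cyclohexyl group on the same aromatic carbon, and in this assay compound 2 likewise gives only a limit, > 1000 nM. The step that the two limits leave unreadable from compound 1 to compound 2 cannot be read because the limit of > 1000 nM in this assay, at which 2 of the 3 values shown sit, fixes neither end of it. Among the measured compounds shown here, compound 3 `Cc1cc(C)cc(NS(=O)(=O)c2ccc(N3CCNC3=O)cc2)c1` in this assay gives 100 nM, the one value here that is an actual number. The unmeasured compound 4 `O=C1NCCN1c1ccc(S(=O)(=O)Nc2ccc(F)cc2)cc1` differs from compound 2 by fluoro in place of cyclohexyl on an aromatic carbon. For the measured compounds named here, no measured step covers this change: the only step with both ends measured has no readable size, and compound 3 is not joined to compound 2 by a single change. Since compound 2 sits at a limit, the step of an at least 1.2-fold lower number from compound 2 to compound 4 (0.09 log units; that floor lies within the scatter) is expected to remain poorly defined, with a fair chance that compound 4 also ends at a limit. Compound 4 is estimated at 800 nM, within 100 nM to 5000 nM.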

Compound 4, half-maximal inhibitory concentration: 690 nM
The estimate for compound 4 lay 1.2-fold (0.06 log units) above the measured number; low and high end bracket the measured number.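

Replacing the cyclohexyl on this aromatic carbon with a fluoro gives, in this assay, an at least 1.4-fold lower number from compound 2 to compound 4 (0.16 log units; that floor lies within the scatter), and replacing the pentyl there gives an at least 1.4-fold lower number from compound 1 to compound 4 (0.16 log units; that floor lies within the scatter); both sizes are only floors, and the step between compound 1 and compound 2 cannot be read: the limit of > 1000 nM in this assay, at which 2 of the 4 values shown sit.

The new value does give this position its first readable comparison with a fluoro in place, and on the sulfonamide nitrogen, 4-fluorophenyl in place of 3,5-dimethylphenyl gives a 6.9-fold higher number from compound 3 to compound 4 (0.84 log units; beyond the scatter). Among these compounds, then, the 3,5-dimethylphenyl of compound 3 keeps the lower number.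

The compounds shown leave open how a chloro, a methoxy or an amine on this same carbon would compare with the fluoro. They also leave open whether a single methyl on the ring would behave like the two in compound 3.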